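The source may hold more compounds than are shown below. What is called first, only, known or untested is meant among the compounds shown, and "the series" means these compounds.

Measured so far in a physicochemical assay for solubility, with a stated time of 18 h, at pH 7.4; on this read-out higher numbers stand for higher solubility and lower numbers for lower solubility: compound 1 `COc1ccc(F)cc1CNCCCNc1ccnc2cc(Cc3ccc(C#N)cc3)ccc12` gives 4200 nM, compound 2 `COc1cccc(CNCCCNc2ccnc3cc(Cc4ccc(C#N)cc4)ccc23)c1O` gives 4200 nM, and compound 3 `COc1ccc(F)cc1CNCCCNc1ccnc2cc(-c3ccc(C(F)(F)F)cc3)ccc12` gives 32000 nM.

Compound 2 differs from compound 1 by 2-hydroxy-3-methoxyphenyl in place of 5-fluoro-2-methoxyphenyl on a saturated chain carbon bound to an amine nitrogen, and that change gave no change at the digits printed from compound 1 to compound 2 (within the scatter). Compound 3 differs from compound 1 in its core: 4-(trifluoromethyl)phenyl in place of 4-cyanobenzyl on an aromatic carbon, a change that gave a 7.6-fold higher number from compound 1 to compound 3 (0.88 log units; beyond the scatter). Compound 4 `COc1cccc(CNCCCNc2ccnc3cc(-c4ccc(C(F)(F)F)cc4)ccc23)c1O` has not yet been measured in this assay. It differs from compound 3 by 2-hydroxy-3-methoxyphenyl in place of 5-fluoro-2-methoxyphenyl on a saturated chain carbon bound to an amine nitrogen, at the same place as the change from compound 1 to compound 2, so it is the same change carried onto the core of compound 3. Because that earlier change gave no change at the digits printed from compound 1 to compound 2 (within the scatter), the step from compound 3 to compound 4 is expected to be no change at the digits printed from compound 3 to compound 4 (within the scatter). Compound 4 is therefore estimated at 32000 nM, most likely between 12000 nM and 80000 nM.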

Compound 4, solubility: 32000 nM
Beside the measured number, compound 4's estimate shows no gap at the digits printed; low and high end bracket the measured number.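

In this assay, the swap to 2-hydroxy-3-methoxyphenyl gave no change at the digits printed from compound 3 to compound 4 (within the scatter) on the new core, just as it gave no change at the digits printed from compound 1 to compound 2 (within the scatter) on the old one, and the core change gave a 7.6-fold higher number from compound 2 to compound 4 (0.88 log units; beyond the scatter) with this group in place, matching a 7.6-fold higher number from compound 1 to compound 3 (0.88 log units; beyond the scatter) with the other. So the two changes behave independently in these four compounds, but that is one pair of cores and cannot be taken as a rule for the series. Nothing given here explains why the swap leaves the number unmoved.

Still open, as far as these compounds go, is whether the swap would hold on a core carrying a carboxylic acid or an amine in place of 4-(trifluoromethyl)phenyl. A longer chain in place of the present one also remains untested among the compounds shown.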